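Swapping a methoxyphenyl for a dichlorophenyl on the benzylamine

The source may hold more compounds than are shown below. What is called first, only, known or untested is meant among the compounds shown, and "the series" means these compounds.

Three sulfonamides share one core: compound 1 `O=S(=O)(NCCCNCc1cccc2ccccc12)c1cc(C(F)(F)F)cc(C(F)(F)F)c1`, compound 2 `O=S(=O)(NCCCNCc1ccccc1Cl)c1cc(C(F)(F)F)cc(C(F)(F)F)c1` and compound 3 `COc1ccccc1CNCCCNS(=O)(=O)c1cc(C(F)(F)F)cc(C(F)(F)F)c1`. In a toxicity assay on MCF-10A cells (Homo sapiens) for inhibition, read by MTT assay, with a stated time of 72 h (on this read-out lower numbers stand for stronger inhibition of growth and higher numbers for weaker inhibition of growth), compound 1 gives 3200 nM, compound 2 gives 11000 nM and compound 3 gives 5500 nM, so compound 3 stands second highest of the three, close to both neighbours. Compound 4 `O=S(=O)(NCCCNCc1ccc(Cl)c(Cl)c1)c1cc(C(F)(F)F)cc(C(F)(F)F)c1` has not been tested; it differs from compound 3 by 3,4-dichlorophenyl in place of 2-methoxyphenyl on a saturated chain carbon bound to an amine nitrogen. The closest measured comparison is a 2.0-fold lower number from compound 2 to compound 3 (0.30 log units; within the scatter), an exchange of chloro for methoxy that stayed within the scatter. Compound 4 reverses that exchange and adds a second chlorine, so no step beyond the scatter is expected, leaning to a somewhat higher number. The estimate for compound 4 is 7000 nM, between 3000 nM and 16000 nM, which means an expected 1.3-fold higher number from compound 3 to compound 4 (0.10 log units; within the scatter).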

Compound 4, concentration for 50% growth inhibition: 3000 nM
Estimate against measurement, compound 4: 2.3-fold (0.37 log units) above; low and high end bracket the measured number.
By their numbers in this assay, from the lowest: compounds 4, 1, 3 and 2 (each within the scatter of the next, the first and the last beyond it).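

In this assay, the new clear step on this saturated chain carbon is a 3.7-fold lower number from compound 2 to compound 4 (0.56 log units; beyond the scatter), so two chlorine-bearing rings can differ here, whereas earlier only naphthalen-1-yl and 2-chlorophenyl stood apart. By contrast, a 1.8-fold lower number from compound 3 to compound 4 (0.26 log units; within the scatter) and a 1.1-fold lower number from compound 1 to compound 4 (0.03 log units; within the scatter) both stay within the scatter, so 3,4-dichlorophenyl cannot be ranked against 2-methoxyphenyl or naphthalen-1-yl. No available evidence explains these results.

As far as these compounds go, whether 3-chlorophenyl or 4-chlorophenyl alone would behave like 3,4-dichlorophenyl remains open. So does what a longer chain in the shared core would do.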